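A few compounds are considered here, and "the series" means these few. Any claim that something is new, unique, unknown or untested is made for them only; others in the source may bear on it.

Measured compounds in a functional assay on A549 cells (Homo sapiens) for cytotoxicity, read by XTT assay, with a stated time of 24 h; on this read-out lower numbers stand for stronger inhibition and higher numbers for weaker inhibition:
- compound 1, `Cn1nnnc1SCC(=O)N/N=C/c1ccc([N+](=O)[O-])cc1`, gives 632000 nM
- compound 2, `Cc1ccc(/C=N/NC(=O)CSc2nnnn2C)cc1`, gives 3160000 nM
- compound 3, `Cn1nnnc1SCC(=O)N/N=C/c1ccc(Br)cc1`, gives only the limit > 10000000 nM

All three share one core and differ only in the group carried on the six-membered aromatic ring of carbon only. Within the numbers shown, compound 2 stands highest: the step of a 5.0-fold higher number from compound 1 to compound 2 (0.70 log units; beyond the scatter) is beyond the scatter, while for compound 3 the value is a limit of the assay, as noted in the limit of > 10000000 nM in this assay, at which 1 of the 3 values shown sits, so its distance from compound 2 cannot be counted.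

Compound 4, `Cn1nnnc1SCC(=O)N/N=C/c1ccc(O)cc1`, arises from compound 2 by the change (hydroxy in place of methyl on an aromatic carbon). Among the compounds with values here, no measured step exchanges a methyl for a hydroxy; the nearest points of reference are the steps of a 5.0-fold higher number from compound 1 to compound 2 (0.70 log units; beyond the scatter) and an at least 3.1-fold higher number from compound 2 to compound 3 (0.50 log units; beyond the scatter), which show that a change of this group alone can move the number by a modest amount in either direction. Without closer evidence, compound 4 is expected to sit near compound 2, with the step of a 1.3-fold higher number from compound 2 to compound 4 (0.10 log units; within the scatter) being the estimate. Compound 4 is therefore estimated at 4000000 nM, between 1000000 nM and 12000000 nM.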

Compound 4, half-maximal inhibitory concentration: > 10000000 nM
Compound 4: a limit, no number; the forecaster's own chance of this, stated with the estimate: 35%; at least 2.5-fold (0.39 log units) between middle value and limit.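

Placing hydroxy, which brings a hydrogen-bond donor and a hydrogen-bond acceptor, on this aromatic carbon in place of methyl gives, in this assay, an at least 3.1-fold higher number from compound 2 to compound 4 (0.50 log units; beyond the scatter), so methyl now has a higher-number neighbour in hydroxy as well as in bromo. Against nitro the gap is larger, an at least 15-fold higher number from compound 1 to compound 4 (1.19 log units; beyond the scatter), and compound 1 keeps the lowest number of the four. Compound 4 gives only a limit, > 10000000 nM, and compound 3 also stands at a limit, so the step between them cannot be read: the limit of > 10000000 nM in this assay, at which 2 of the 4 values shown sit.

The four groups shown leave open whether an amine or a carboxylic acid at this position would give a number lower than that of compound 1 or would also reach the limit. They also leave open how changes elsewhere on the shared core would move the number.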